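This account rests on a few compounds, and the source may have more. Where it says the series, first, only, none or still open, it means among the compounds named here.

In a functional assay on HL-60 cells (Homo sapiens), with a stated time of 4 days (on this read-out higher numbers stand for weaker inhibition and lower numbers for stronger inhibition), the three measured compounds stand as follows.
Compound 1 `CCCCCCNC(=O)c1[nH]cnc1C(=O)Nc1ccc(Cl)c(Cl)c1`: 7800 nM
Compound 2 `C[C@H](NC(=O)c1[nH]cnc1C(=O)Nc1ccc(Cl)c(Cl)c1)c1ccccc1`: 5900 nM
Compound 3 `COC(=O)[C@@H](C)NC(=O)c1[nH]cnc1C(=O)Nc1ccc(Cl)c(Cl)c1`: > 62500 nM, a limit of the assay and not a number

Compound 3 sits at the limit of > 62500 nM in this assay, at which 1 of the 3 values shown sits; its value is a limit, so its true number is not known. Within the measured set, an at least 8.0-fold higher number from compound 1 to compound 3 (0.90 log units; beyond the scatter) and an at least 10-fold higher number from compound 2 to compound 3 (1.02 log units; beyond the scatter) place compound 3 beyond the scatter from both others, whereas a 1.3-fold lower number from compound 1 to compound 2 (0.12 log units; within the scatter) lies within the scatter.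

Compound 4 `COC(=O)[C@H](NC(=O)c1[nH]cnc1C(=O)Nc1ccc(Cl)c(Cl)c1)c1ccccc1` differs from compound 3 by phenyl in place of methyl on a saturated chain carbon bound to an amide-type nitrogen and a carbonyl carbon. The nearest measured step is the one in which a phenyl-bearing chain replaces hexyl on the amide-type nitrogen, a 1.3-fold lower number from compound 1 to compound 2 (0.12 log units; within the scatter), which gave no change beyond the scatter. Both measured steps that bring in the 1-(methoxycarbonyl)ethyl group, an at least 8.0-fold higher number from compound 1 to compound 3 (0.90 log units; beyond the scatter) and an at least 10-fold higher number from compound 2 to compound 3 (1.02 log units; beyond the scatter), lie beyond the scatter, and compound 4 keeps the methoxycarbonyl group on that chain. For compound 4 a step of no more than the scatter is therefore expected, an at least 1.0-fold lower number from compound 3 to compound 4 (0.01 log units; that floor lies within the scatter). Compound 4 is estimated at 60000 nM, range 20000 nM to 200000 nM, with a fair chance that this assay again reports only a limit.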

Compound 4, half-maximal inhibitory concentration: 10800 nM
For compound 4 the middle estimate is 5.6-fold (0.74 log units) above the measured one, outside the stated range (below it).
By their numbers in this assay, from the lowest: compounds 2, 1 and 4 (each within the scatter of the next). At a limit, above all of these: compound 3.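

With the methoxycarbonyl group kept, phenyl in place of methyl on a saturated chain carbon bound to an amide-type nitrogen and a carbonyl carbon gives an at least 5.7-fold lower number from compound 3 to compound 4 (0.76 log units; beyond the scatter) in this assay, so the methoxycarbonyl group alone does not carry compound 3 to its limit. Compound 3 stands at a limit and not a number, so this step gives only a floor and its full size stays unknown: the limit of > 62500 nM in this assay, at which 1 of the 4 values shown sits.

Methoxycarbonyl in place of methyl on a saturated chain carbon bound to an amide-type nitrogen and an aromatic carbon gives a 1.8-fold higher number from compound 2 to compound 4 (0.26 log units; within the scatter), so with phenyl on that carbon the swap stays within the scatter, unlike the methoxycarbonyl steps read earlier with methyl on that carbon.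

Going by these compounds, whether phenyl is specifically needed on that carbon stays open, since a benzyl or cyclohexyl group there could serve equally well or fail. On these data alone, it is also open whether the tolerance extends past the methyl ester to a carboxylic acid or a primary amide in that place when phenyl is kept.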